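The source may report more compounds than this note shows. Statements on the series, on what has been measured and on what is new or still open speak of the compounds shown alone.

Working notes on the series. In an ADME assay on J774 cells (Mus musculus) for antiproliferative activity, with a stated time of 72 h (a lower number here means that less compound is needed, a higher number that more compound is needed for the effect), compound 1 `CCCCc1cc2c(=O)c(CC)c(C)[nH]c2cc1OCCOc1ccccc1` gives 1000 nM, the lowest of the two actual numbers, and compound 3 `CCc1c(C)[nH]c2cc(OCCOc3ccccc3)ccc2c1=O` is nearest at 4000 nM. Compound 2 `CCc1c(C)[nH]c2cc(OCCOc3ccccc3)c(C)cc2c1=O` stands at > 30000 nM, which is a limit and not a number.

Compound 4 `CCCCc1cc2c(=O)c(-c3ccncc3)c(C)[nH]c2cc1OCCOc1ccccc1` has the structure of compound 1 with pyridin-4-yl in place of ethyl on an aromatic carbon. Among the compounds with values here, no measured step touches that place. The steps at hand concern other groups: hydrogen in place of propyl gave an at least 30-fold higher number from compound 1 to compound 2 (1.47 log units; beyond the scatter), hydrogen in place of butyl gave a 4.0-fold higher number from compound 1 to compound 3 (0.60 log units; beyond the scatter), and hydrogen in place of methyl gave an at least 7.5-fold lower number from compound 2 to compound 3 (0.87 log units; beyond the scatter). These range from modest to large, but they fix neither size nor direction for the new change. Compound 4 keeps the butyl group, so the loss seen in a 4.0-fold higher number from compound 1 to compound 3 (0.60 log units; beyond the scatter) should not apply. A modest rise in this assay is expected, with low confidence. The expected step is a 2.5-fold higher number from compound 1 to compound 4 (0.40 log units; beyond the scatter). Compound 4 is estimated at 2500 nM, with an expected range of 500 nM to 15000 nM.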

Compound 4, half-maximal effective concentration: 23000 nM
Estimate against measurement, compound 4: 9.2-fold (0.96 log units) below, and the stated range ends below it.
By their numbers in this assay, from the lowest: compound 1; then compound 3; then compound 4. At a limit, above all of these: compound 2.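

In this assay, within the data shown here, pyridin-4-yl in place of ethyl gives a 23-fold higher number from compound 1 to compound 4 (1.36 log units; beyond the scatter) as a large step at a place the earlier steps did not touch. Among these compounds, this is the first reading for this place on the shared core, and it shows that keeping the butyl group does not hold compound 4 near compound 1 when the ethyl group is replaced by this ring. Compound 2 alone stands at a limit, which is not a number: the limit of > 30000 nM in this assay, at which 1 of the 4 values shown sits.

With a single replacement here, the compounds shown do not separate the effect of the ring nitrogen from that of the added ring itself; phenyl, pyridin-3-yl or a longer chain such as propyl at this place would address that. Also open, as far as these compounds go, is whether pyridin-4-yl gives a step of similar size on a core without the butyl group.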